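This account rests on a few compounds, and the source may have more. Where it says the series, first, only, none or still open, it means among the compounds named here.

Measured compounds:
Compound 2, `C#CCN(C)Cc1cc2ccccc2n1C`: in an assay on isolated protein for inhibition of Amine oxidase [flavin-containing] B (Rattus norvegicus) (a higher number here means a weaker inhibitor, a lower number a stronger inhibitor), compound 2 gives 3 nM.
Compound 1, `CC#CCN(C)Cc1cc2cc(OC)ccc2n1C`: in this assay compound 1 gives 370 nM.

Among the measured compounds shown here, compound 2 holds the lowest of the two inhibition constants; compound 1, the only other measured compound, shows a gap beyond the scatter. Compound 3, `CC#CCN(C)Cc1cc2ccccc2n1C`, differs from compound 2 by methyl in place of hydrogen on a triple-bonded carbon. For the measured compounds named here, no measured pair isolates this change; compound 1 carries it together with a second change and shows a far higher number, so a loss beyond the scatter is expected. Compound 3 is expected at 100 nM, between 20 nM and 600 nM, a step of a 33-fold higher number from compound 2 to compound 3 (1.52 log units; beyond the scatter).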

Compound 3, inhibition constant: 30 nM
For compound 3 the middle estimate is 3.3-fold (0.52 log units) above the measured one; the measured number falls inside the stated range.
By their numbers in this assay, from the lowest: compound 2; then compound 3; then compound 1.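

Compound 3 separates the two changes that compound 1 carries together. Methyl in place of hydrogen on a triple-bonded carbon gives, on its own, a 10-fold higher number from compound 2 to compound 3 (1.00 log units; beyond the scatter) in this assay and hydrogen in place of methoxy on an aromatic carbon gives a 12-fold lower number from compound 1 to compound 3 (1.09 log units; beyond the scatter) as the other single change, so each change alone moves the inhibition constant beyond the scatter. Nothing measured here explains either step. Still open, as far as these compounds go, is how an ethyl or a longer chain on that triple-bonded carbon would behave, and whether a fluorine or hydroxy group in place of methoxy would cost as much.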